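Adding a 5-cyanopentyl chain to compound 3: solubility outlook

This account rests on a few compounds, and the source may have more. Where it says the series, first, only, none or still open, it means among the compounds named here.

Of the compounds shown here, three sharing one core have been measured in a physicochemical assay for solubility, in phosphate buffer, with a stated time of 18 h; a higher number here means a more soluble compound, a lower number a less soluble compound. Compound 1 `CC(C)Cc1ncc2c(N)c(C#N)c(N)nc2n1` gives 268000 nM, compound 2 `N#Cc1c(N)nc2nc(Cc3ccccc3)ncc2c1N` gives 13000 nM, and compound 3 `CC(C)(C)c1ncc2c(N)c(C#N)c(N)nc2n1` gives 37200 nM. Compound 3 stands second highest of the three: a 2.9-fold higher number from compound 2 to compound 3 (0.46 log units; beyond the scatter), while a 7.2-fold lower number from compound 1 to compound 3 (0.86 log units; beyond the scatter). The remaining step, a 21-fold lower number from compound 1 to compound 2 (1.31 log units; beyond the scatter), links the other two.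

Compound 4 `CC(C)(C)c1nc(CCCCCC#N)c2c(N)c(C#N)c(N)nc2n1` is the next structure. The change from compound 3 to compound 4 is 5-cyanopentyl in place of hydrogen on an aromatic carbon. The change sits on an aromatic carbon of the shared core, meta to the tert-butyl group, and it places a new group where only hydrogen stood before.

Among the measured compounds shown here, none of the measured steps is a direct match: each of them swaps one carbon group for another on the same aromatic carbon rather than growing a chain from hydrogen. They do show that every reshaping of the substituents in this set moved this assay by a modest to large amount, and that the larger benzyl group in compound 2 sits lowest. Compound 4 carries a larger structure than compound 3, so a modest lowering is expected, a 2.5-fold lower number from compound 3 to compound 4 (0.39 log units; beyond the scatter), giving an estimated 15000 nM for compound 4, with a range from 4000 nM to 60000 nM.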

Compound 4, solubility: 6000 nM
Beside the measured number, compound 4's estimate is 2.5-fold (0.40 log units) above it, within the range that was stated.
By their numbers in this assay, from the lowest: compound 4; then compound 2; then compound 3; then compound 1.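

In this assay, among the compounds shown here, the earlier steps only exchanged one carbon group for another, while this one places 5-cyanopentyl where hydrogen stood, on an aromatic carbon next to the ring nitrogen and meta to a tert-butyl group, and it gives a 6.2-fold lower number from compound 3 to compound 4 (0.79 log units; beyond the scatter). For the compounds shown here, compounds 1, 2 and 3 all carry hydrogen at this carbon, so they could say nothing about it; this step is the first sign that a substituent here moves the number by more than the usual scatter. The step reports only the size of the whole change, and no measurement here explains it.

A single chain cannot separate the contribution of its carbon length from that of its end nitrile, so a plain hexyl chain, a shorter cyanoalkyl chain, or a chain ending in an amine or a carboxylic acid would each be needed to tell them apart. As far as these compounds go, it also remains open whether the same chain would lower the number to a similar degree with the isobutyl group of compound 1 or the benzyl group of compound 2 in place of tert-butyl.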